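Adding bromo to compound 2: working notes

A few compounds are considered here, and "the series" means these few. Any claim that something is new, unique, unknown or untested is made for them only; others in the source may bear on it.

Measured in a functional assay on HT-29 cells (Homo sapiens) for cytotoxicity, read by sulforhodamine B assay, with a stated time of 72 h (on this read-out higher numbers stand for weaker inhibition of growth and lower numbers for stronger inhibition of growth), as follows:
- compound 1 `COn1cc(C2CC(=O)N=C(N)N2)c2ccccc21` gives "not active" (no number reported)
- compound 2 `Cn1cc(C2CCN=C(N)N2)c2ccccc21` gives 4290 nM
- compound 3 `COn1cc(C2CCN=C(N)N2)c2ccccc21` gives "not active" (no number reported)

Within this assay only compound 2 has a number, at 4290 nM against two entries without one. That value is therefore the sole numerical anchor, and it cannot be ranked against compound 1 or compound 3 by size.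

The unmeasured compound 4 `Cn1cc(C2CCN=C(N)N2)c2cc(Br)ccc21` differs from compound 2 by one change: bromo in place of hydrogen on an aromatic carbon with bromo in place of hydrogen on an aromatic carbon. Within the data shown here, no step between measured compounds is available, so the series offers no direct precedent for this change. A modest move towards stronger inhibition of growth is expected, though a result without a number remains possible. The expected 2.4-fold lower number from compound 2 to compound 4 (0.38 log units; beyond the scatter) is small and uncertain in size. For compound 4 the estimated value is 1800 nM with an expected range from 400 nM to 7000 nM in this assay on this reasoning.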

Compound 4, concentration for 50% growth inhibition: 13700 nM
Beside the measured number, compound 4's estimate is 7.6-fold (0.88 log units) below it; measured number above the stated range.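

In this assay bromo in place of hydrogen on an aromatic carbon gives a 3.2-fold higher number from compound 2 to compound 4 (0.50 log units; beyond the scatter) and so moves towards weaker inhibition of growth. Among these compounds, this is the first step that can be read as a number, and it shows that this carbon, on a six-membered aromatic ring of carbon only, meta to a fused ring and para to a fused ring, responds to substitution. The change leaves a measurable value, with compound 4 at 13700 nM, but a single step cannot separate an effect of bromo from an effect of this position, and no measurement at hand explains the shift.

Still open, as far as these compounds go, is whether a chloro group, an amine or a carboxylic acid on the same carbon would move the number in the same direction. Also open, from the compounds shown here alone, is whether bromo on another carbon of that ring would give a similar step.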